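Swapping the hydroxy-bearing ring of compound 3

The source may report more compounds than this note shows. Statements on the series, on what has been measured and on what is new or still open speak of the compounds shown alone.

Values measured so far in a functional assay on SW480 cells (Homo sapiens) for antiproliferative activity, read by sulforhodamine B assay, with a stated time of 48 h; a lower number here means a stronger inhibitor, a higher number a weaker inhibitor
Compound 1 `COc1cccc(/C=C/C(=O)C(=Cc2cc(OC)c(OC)c(OC)c2)C(=O)/C=C/c2cccc(OC)c2OC)c1OC` gives 650 nM
Compound 2 `COc1cc(C=C(C(=O)/C=C/c2cccc(OC)c2OC)C(=O)/C=C/c2cccc(OC)c2OC)cc(Br)c1O` gives 260 nM
Compound 3 `COc1cc(C=C(C(=O)/C=C/c2cccc(OC)c2OC)C(=O)/C=C/c2cccc(OC)c2OC)cc(OC)c1O` gives 420 nM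

Compound 3 lies within the scatter of both other compounds, although they are separated by a 2.5-fold lower number from compound 1 to compound 2 (0.40 log units; beyond the scatter) in this series. The next compound is compound 4 `COc1cccc(/C=C/C(=O)C(=Cc2ccc(OC)c(OC)c2OC)C(=O)/C=C/c2cccc(OC)c2OC)c1OC`, with this change: 2,3,4-trimethoxyphenyl in place of 4-hydroxy-3,5-dimethoxyphenyl on a double-bonded chain carbon bound to a double-bonded chain carbon here. The closest evidence is a 1.5-fold lower number from compound 1 to compound 3 (0.19 log units; within the scatter) for a similar exchange of hydrogen and methyl on an oxygen. Also relevant is a 1.6-fold higher number from compound 2 to compound 3 (0.21 log units; within the scatter) at the same group. Going by the values given here, no measured compound carries 2,3,4-trimethoxyphenyl at this place, so the range stays wide. The expected result in this assay is a 1.3-fold higher number from compound 3 to compound 4 (0.12 log units; within the scatter) and no step beyond the scatter is expected. For compound 4 the estimate is 550 nM with an expected range of 250 nM to 1200 nM overall.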

Compound 4, half-maximal inhibitory concentration: 560 nM
The estimate for compound 4 lay 1.0-fold (0.01 log units) below the measured number; the range from low to high includes it.
By their numbers in this assay, from the lowest: compounds 2, 3, 4 and 1 (each within the scatter of the next, the first and the last beyond it).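

In this assay, 2,3,4-trimethoxyphenyl on this double-bonded chain carbon stays within the scatter of both 4-hydroxy-3,5-dimethoxyphenyl (a 1.3-fold higher number from compound 3 to compound 4 (0.12 log units; within the scatter)) and 3,4,5-trimethoxyphenyl (a 1.2-fold lower number from compound 1 to compound 4 (0.06 log units; within the scatter)). Among these three compounds, neither the hydroxy group nor this rearrangement of methoxy groups produces a step beyond the scatter. Only 3-bromo-4-hydroxy-5-methoxyphenyl stands apart from it (a 2.2-fold higher number from compound 2 to compound 4 (0.33 log units; beyond the scatter)), and no measurement at hand accounts for this. Going by these compounds, whether an amine or a carboxylic acid on this ring would keep the number in this range remains open.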